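The source may report more compounds than this note shows. Statements on the series, on what has been measured and on what is new or still open speak of the compounds shown alone.

Values in an ADME assay on L929 cells (Mus musculus) for cytotoxicity, read by resazurin assay, with a stated time of 48 h; a lower number here means that less compound is tolerated, a higher number that more compound is tolerated:
- Compound 1 `CNC(=O)CCCn1c2ccc([N+](=O)[O-])cc2c(=O)n1Cc1ccccc1`: > 256000 nM, a limit.
- Compound 2 `O=C(c1ccccc1)n1c2ccc([N+](=O)[O-])cc2c(=O)n1Cc1ccccc1`: 146000 nM.
- Compound 3 `O=[N+]([O-])c1ccc2nn(Cc3ccccc3)c(OCCBr)c2c1`: > 256000 nM, a limit.

Compound 3 stands at the limit of > 256000 nM in this assay, at which 2 of the 3 values shown sit. Compound 4 `CCOC(=O)CCCOc1c2cc([N+](=O)[O-])ccc2nn1Cc1ccccc1` is still unmeasured and differs from compound 3 by (ethoxycarbonyl)methyl in place of bromo on a saturated chain carbon, two bonds along the chain from an oxygen on an aromatic ring. Within the data shown here, the only measured step, an at least 1.7-fold lower number from compound 1 to compound 2 (0.24 log units; that floor lies within the scatter), is a change on an aromatic nitrogen and not on this chain. Its floor lies within the scatter, so it gives no size for the present change. No shift beyond the scatter is therefore expected in this assay, and no direction can be argued. The expected step is an at least 1.1-fold lower number from compound 3 to compound 4 (0.06 log units; that floor lies within the scatter). For compound 4 the estimate is 220000 nM, with an expected range of 100000 nM to 400000 nM.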

Compound 4, concentration lethal to 50% of the cells: > 256000 nM
Compound 4 ended at the assay's limit; the forecaster's own chance of this, stated with the estimate: 60%; middle value at least 1.1-fold (0.06 log units) away from the limit.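

In this assay, compound 3 and compound 4 both sit at a limit, so no step can be read between them: the limit of > 256000 nM in this assay, at which 3 of the 4 values shown sit.

The compounds shown leave open whether 2-bromoethoxy and 3-(ethoxycarbonyl)propoxy differ at all in cell tolerance.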